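From a Chlorophenyl to a Naphthyl on the Shared Core

This account rests on a few compounds, and the source may have more. Where it says the series, first, only, none or still open, it means among the compounds named here.

Compound 1 `N#CC1=C(N)OC(c2c[nH]c3ccccc23)=C(C#N)C1c1ccccc1`, compound 2 `N#CC1=C(N)OC(c2c[nH]c3ccccc23)=C(C#N)C1c1ccc(F)cc1` and compound 3 `N#CC1=C(N)OC(c2c[nH]c3ccccc23)=C(C#N)C1c1ccccc1Cl` share one core and differ only in the group on a saturated ring carbon. In a functional assay, tested at 400 ug/mL (on this read-out lower numbers stand for a weaker effect and higher numbers for a stronger effect at the one concentration tested), compound 1 gives 26.7%, compound 2 gives 26.7% and compound 3 gives 21.4%, the lowest number of the three, though the gaps a number 5.3 percentage points lower from compound 1 to compound 3 (within the scatter) and a number 5.3 percentage points lower from compound 2 to compound 3 (within the scatter) both lie within the scatter, as does no change at the digits printed from compound 1 to compound 2 (within the scatter). Compound 4 `N#CC1=C(N)OC(c2c[nH]c3ccccc23)=C(C#N)C1c1ccc2ccccc2c1` differs from compound 3 in one place: naphthalen-2-yl in place of 2-chlorophenyl on a saturated ring carbon. For the measured compounds named here, every measured step so far changed that same group, and none moved the read-out beyond the scatter, so the step to compound 4 is expected to be small as well, a number 2.6 percentage points higher from compound 3 to compound 4 (within the scatter). Compound 4 is therefore estimated at 24%, between 12% and 36%.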

Compound 4, a percentage reported as activity, at one concentration (the size of the read-out at that concentration, not a potency): "not active" (no number reported)
Compound 4: no number reported; no gap can be computed for the estimate.
By their numbers in this assay, from the lowest: compounds 3, 1 and 2 (each within the scatter of the next).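

For the compounds shown here, compound 4 is reported only as "not active", with no number, so no step from compound 3 to compound 4 can be read. No evidence shown bears on this result. The compounds shown leave open whether compound 4 truly differs from compound 3 in this assay.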